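The compounds below may be only part of what the source reports. "The series", "measured", "known", "first", "only" and "open" are said of these compounds alone.

Compound 1, `CC(C)(C)NCc1cc(Cl)cc(Nc2nc3ccccc3[nH]2)c1O`: > 50000 nM
Compound 2, `CC(C)(C)NCc1cc(C(C)(C)C)cc(Nc2nc3cc(F)c(F)cc3[nH]2)c1O`: 34200 nM
Compound 3, `CCN(CC)Cc1cc(F)cc(Nc2nc3ccccc3n2Cc2ccc(C(F)(F)F)cc2)c1O`: > 50000 nM

In an ADME assay on CHO cells (Cricetulus griseus) for inhibition, read by MTT assay (a higher number here means a weaker inhibitor, a lower number a stronger inhibitor), compound 1 returns only a limit, > 50000 nM. Compound 2 gives a number, 34200 nM. Compound 3 likewise returns only a limit, > 50000 nM, so among the values shown it stands at the limit of > 50000 nM in this assay, at which 2 of the 3 values shown sit, rather than at any number.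

Compound 4, `CCN(CC)Cc1cccc(Nc2nc3ccccc3n2Cc2ccc(C(F)(F)F)cc2)c1O`, has not yet been measured in this assay. It differs from compound 3 in one place: hydrogen in place of fluoro on an aromatic carbon. For the measured compounds named here, no step between measured compounds is available to guide the size of this change. Removing a single fluorine is expected to move this assay by no more than the scatter, in no set direction. Compound 4 is therefore estimated at 60000 nM, in the range 25000 nM to 150000 nM. The expected step that the limit leaves unreadable from compound 3 to compound 4 is within the scatter.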

Compound 4, half-maximal inhibitory concentration: > 50000 nM
Compound 4: a limit, no number; the forecaster's own chance of this, stated with the estimate: 70%; the middle value does not contradict the limit.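

In this assay compound 3 and compound 4 each return only a limit, so the step between them cannot be read. The compounds shown leave open whether hydrogen in place of fluoro on an aromatic carbon changes inhibition at all.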